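Trimethoxyphenyl for hydroxyphenyl on the chalcone carbonyl

The compounds below may be only part of what the source reports. "The series", "measured", "known", "first", "only" and "open" are said of these compounds alone.

Compound 3 `COC(=O)c1cc(-c2cccc(NC(=O)c3ccc(/C=C/C(=O)c4ccc(O)cc4)cc3)c2)on1` carries a 4-hydroxyphenyl on the carbonyl carbon of the enone. In an ADME assay on Vero cells (Chlorocebus sabaeus) for cytotoxicity, read by MTT assay, with a stated time of 72 h (on this read-out lower numbers stand for higher toxicity in this test and higher numbers for lower toxicity in this test), compound 3 gives "not determined" (no result reported), so no single number stands for it. Only compound 1 and compound 2 have values, and each of those is a limit of the assay. In this assay compound 1 `COC(=O)c1cc(-c2cccc(NC(=O)c3ccc(/C=C/C(=O)c4ccccc4)cc3)c2)on1` gives only a limit, > 50 ug/mL. In this assay compound 2 `COC(=O)c1cc(-c2cccc(NC(=O)c3ccc(/C=C/C(=O)c4ccc(OC)cc4)cc3)c2)on1` also gives only a limit, > 10 ug/mL. Within the data shown here, the step that the two limits leave unreadable from compound 1 to compound 2 is therefore unreadable, as the two limits the limit of > 50 ug/mL in this assay, at which 1 of the 3 values shown sits, and the limit of > 10 ug/mL in this assay, at which 1 of the 3 values shown sits, hide its size; no measured step bears on the change now considered.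

Compound 4 `COC(=O)c1cc(-c2cccc(NC(=O)c3ccc(/C=C/C(=O)c4cc(OC)c(OC)c(OC)c4)cc3)c2)on1` differs from compound 3 by 3,4,5-trimethoxyphenyl in place of 4-hydroxyphenyl on a carbonyl carbon. With no readable step and no number for compound 3, the expectation rests only on the two limits of the series, and no direction beyond the scatter can be claimed. In this assay compound 4 is estimated at 40 ug/mL, within a range of 10 ug/mL to 100 ug/mL, with a fair chance that only a limit is again reported.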

Compound 4, half-maximal cytotoxic concentration: > 50 ug/mL
Compound 4: no number, only a limit; the forecaster's own chance of this, stated with the estimate: 60%; middle value at least 1.2-fold (0.09 log units) away from the limit.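

No new step can be read from compound 4 to compound 1 or compound 2: in this assay, all three compounds give only limits. As far as these compounds go, what stays open is the size of any change in half-maximal cytotoxic concentration among phenyl, 4-methoxyphenyl and 3,4,5-trimethoxyphenyl on the carbonyl carbon.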